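The compounds below may be only part of what the source reports. "The series", "measured", "known", "first", "only" and "open" are said of these compounds alone.

Measured compounds:
compound 1 `CC1(C)c2[nH]nc(NC(=O)c3ccccc3)c2CN1Cc1ccc(F)cc1`, which in an assay on Sf21 cells for inhibition of high affinity nerve growth factor receptor (Homo sapiens), read by HTRF, with a stated time of 30 min, in the presence of a further agent that is not named here (a higher number here means a weaker inhibitor, a lower number a stronger inhibitor), gives 1180 nM
compound 2 `CC1(C)c2[nH]nc(NC(=O)c3ccccc3)c2CN1Cc1c(F)cccc1F`, which in this assay gives 520 nM

For the measured compounds named here, compound 2 stands at the lowest of the two numbers; its nearest neighbour is compound 1, and the step of a 2.3-fold lower number from compound 1 to compound 2 (0.36 log units; beyond the scatter) is the only measured step in this set. Compound 3 `Cc1ccc(F)c(CN2Cc3c(NC(=O)c4ccccc4)n[nH]c3C2(C)C)c1` has not yet been measured. It differs from compound 2 in one place: 2-fluoro-5-methylphenyl in place of 2,6-difluorophenyl on a saturated chain carbon bound to an amine nitrogen in a ring. Going by the values given here, the measured step bears on this change only loosely, since compound 3 keeps one ring fluorine in the 2-fluoro-5-methylphenyl group while the 2,6-difluorophenyl of compound 2 carried two, and the methyl has no counterpart among the measured compounds. One modest step in one direction gives no firm basis for expecting a shift of comparable size. The expectation for compound 3 in this assay is therefore a number close to that of compound 2, with the step of a 1.3-fold higher number from compound 2 to compound 3 (0.13 log units; within the scatter) expected to lie within the scatter. Compound 3 is estimated at 700 nM, in the range 250 nM to 2000 nM.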

Compound 3, half-maximal inhibitory concentration: 880 nM
Compound 3: the middle estimate sits 1.3-fold (0.10 log units) below what was measured; measured number inside the range.
By their numbers in this assay, from the lowest: compounds 2, 3 and 1 (each within the scatter of the next, the first and the last beyond it).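

In this assay, putting 2-fluoro-5-methylphenyl in place of 2,6-difluorophenyl on a saturated chain carbon bound to an amine nitrogen in a ring gives a step within the scatter (a 1.7-fold higher number from compound 2 to compound 3 (0.23 log units; within the scatter)), and set against the 4-fluorophenyl of compound 1 the same group also stays within it (a 1.3-fold lower number from compound 1 to compound 3 (0.13 log units; within the scatter)). Compound 3 thus lies within the scatter of both compound 1 and compound 2, although those two lie beyond the scatter of each other, so this position accepts a ring with one fluorine and one methyl without a step that can be read against either neighbour. No measurement shown here offers an explanation for these numbers.

All of the compounds shown carry a fluorinated phenyl ring at this position, so it remains open whether a plain phenyl, a pyridine or a cyclohexyl group would give numbers in the same range. Also open, going by these compounds, is what the methyl contributes on its own, which compound 3 does not separate from the loss of one fluorine.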